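This account rests on a few compounds, and the source may have more. Where it says the series, first, only, none or still open, it means among the compounds named here.

Working notes on the series.

Compound 1 `Cc1cccc(/C(N)=N/NC(=S)N2CCCCC2)n1` is examined in a functional assay on HeLa cells (Homo sapiens) for cytotoxicity, read by MTT assay, with a stated time of 72 h, tested at 100 uM; a higher number here means more inhibition of growth at the concentration tested, a lower number less inhibition of growth; there compound 1 gives 85.4%, the highest of the three numbers to hand. Compound 2 `N/C(=N\NC(=S)N1CCOCC1)c1ccc(F)cn1` gives 81.2% in this assay, and compound 3 `Cc1cccc(/C(N)=N/NC(=S)N2CCCC2)n1` gives 80.1%. Both lie within the scatter of compound 1, so no order among the three can be claimed. Within the data shown here, the one single-point step that is measured, pyrrolidin-1-yl in place of piperidin-1-yl on a thiocarbonyl carbon, is a number 5.3 percentage points lower from compound 1 to compound 3 (within the scatter), which is within the scatter.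

Compound 4 `N/C(=N\NC(=S)N1CCCCC1)c1ccccn1` has not yet been measured in this assay. It differs from compound 1 by hydrogen in place of methyl on an aromatic carbon. Among the measured compounds shown here, none of the measured steps touches this position, so the only guidance is that the one measured change elsewhere in the core left the number within the scatter, and that the three measured compounds, with and without the methyl on the ring, sit close together. Compound 4 is therefore expected to stay at a similar level, with a step of a number 5.4 percentage points lower from compound 1 to compound 4 (within the scatter) that is expected to fall within the scatter. For compound 4 the estimate in this assay is 80%, with a range from 65% to 92%.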

Compound 4, percent growth inhibition at one concentration: 86%
The estimate for compound 4 lay 6 percentage points below the measured number; the range from low to high includes it.
By their numbers in this assay, from the lowest: compounds 3, 2, 1 and 4 (each within the scatter of the next).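

Hydrogen in place of methyl on an aromatic carbon, next to the ring nitrogen, is now a measured step: in this assay it reads as a number 0.6 percentage points higher from compound 1 to compound 4 (within the scatter), a first direct reading at this position, which none of the earlier steps touched. With the piperidin-1-yl group on the thiocarbonyl carbon, the methyl can therefore be removed without a readable difference at the one concentration tested, and the removal of this single carbon leaves the two compounds indistinguishable in this assay. No measured property bears on this result, so nothing can be said about what lies behind it.

Going by these compounds, this reading rests on one pair, and it stays open whether the same replacement would read alike with the pyrrolidin-1-yl group on the thiocarbonyl carbon or with the morpholine-type ring of compound 2. On these data alone, it also stays open whether a group other than methyl or hydrogen on this aromatic carbon, such as an ethyl, a methoxy, an amine or a carboxylic acid, would stay within the scatter of compound 4 in this assay.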